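The source may hold more compounds than are shown below. What is called first, only, known or untested is meant among the compounds shown, and "the series" means these compounds.

- Compound 1 `O=C(NCc1ccc(S(=O)(=O)c2ccccc2)cc1)c1nc2cnccc2[nH]1`: 5400 nM
- Compound 2 `O=C(NCc1ccc(S(=O)(=O)c2ccccc2)cc1)c1cc2ncccc2s1`: > 10000 nM
- Compound 3 `O=C(NCc1ccc(S(=O)(=O)c2cccc(F)c2)cc1)c1cc2cnccc2[nH]1`: 11 nM

These values come from a functional assay on A2780 cells (Homo sapiens) for inhibition, read by sulforhodamine B assay, with a stated time of 72 h; on this read-out higher numbers stand for weaker inhibition and lower numbers for stronger inhibition. Compound 2 gives only a limit of the assay, > 10000 nM, and not a true number. Compound 4 `O=C(NCc1ccc(S(=O)(=O)c2ccccc2)cc1)c1ccc2nccn2c1` differs from it in one place: a group of 9 heavy atoms (7 carbon, 2 nitrogen; one five-membered aromatic ring with 2 hetero atoms, one six-membered aromatic ring with 1 hetero atom) in place of a group of 9 heavy atoms (7 carbon, 1 nitrogen, 1 sulfur; one five-membered aromatic ring with 1 hetero atom, one six-membered aromatic ring with 1 hetero atom), on a carbonyl carbon. Going by the values given here, the only measured step at this place, an at least 1.8-fold higher number from compound 1 to compound 2 (0.26 log units; that floor lies within the scatter), gives just a floor and says little about size. Compound 3 reaches 11 nM, so low numbers are possible in this family, although compound 3 also differs elsewhere. With that in view, a large downward move is expected, an at least 250-fold lower number from compound 2 to compound 4 (2.39 log units; beyond the scatter). For compound 4 the estimated value is 40 nM, with an expected range of 5 nM to 400 nM.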

Compound 4, half-maximal inhibitory concentration: 13 nM
The estimate for compound 4 lay 3.1-fold (0.49 log units) above the measured number; the range from low to high includes it.
By their numbers in this assay, from the lowest: compounds 3 and 4 (each within the scatter of the next); then compound 1. At a limit, above all of these: compound 2.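

In this assay, changing only the group on the carbonyl carbon, with the same number of heavy atoms, moves the result strongly, and the unfluorinated series also reaches low numbers: a 420-fold lower number from compound 1 to compound 4 (2.62 log units; beyond the scatter). A second step, an at least 760-fold lower number from compound 2 to compound 4 (2.88 log units; beyond the scatter), gives only a floor for the size of the change. Compound 2 stands at a limit and not at a true number: the limit of > 10000 nM in this assay, at which 1 of the 4 values shown sits.

The compounds shown do not tell how a single benzene ring or a longer chain would behave on this carbonyl carbon. They also leave open which atoms of the entering group matter.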